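Series notes: 4-chlorophenyl to 4-bromophenyl

This account rests on a few compounds, and the source may have more. Where it says the series, first, only, none or still open, it means among the compounds named here.

In a functional assay on MCF7 cells (Homo sapiens) for cytotoxicity, read by MTT assay, with a stated time of 72 h (on this read-out higher numbers stand for weaker inhibition and lower numbers for stronger inhibition), compound 2 `Cn1ccc2c(Oc3ccc(NC(=O)c4cc5cccnc5n(-c5ccc(Cl)cc5)c4=O)cc3)ncnc21` gives 95000 nM, within the scatter of compound 1 `Cn1ccc2c(Oc3ccc(NC(=O)c4cc5cccnc5n(-c5ccccc5)c4=O)cc3)ncnc21` at 88400 nM. Compound 3 `Cn1ccc2c(Oc3ccc(NC(=O)c4cc5cccnc5n(-c5ccc(Br)cc5)c4=O)cc3)ncnc21` carries bromo in place of chloro on an aromatic carbon, para to a large group: bromo in place of chloro on an aromatic carbon. Among the compounds with values here, the one measured step bearing on this is a 1.1-fold higher number from compound 1 to compound 2 (0.03 log units; within the scatter), chloro in place of hydrogen on an aromatic carbon, and it stays within the scatter. No change beyond the scatter is therefore expected in this assay, and no direction can be assigned. The expected step is no change at the digits printed from compound 2 to compound 3 (within the scatter). For compound 3 the estimated value is 95000 nM, with an expected range of 50000 nM to 170000 nM.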

Compound 3, half-maximal inhibitory concentration: 79400 nM
Compound 3: the middle estimate sits 1.2-fold (0.08 log units) above what was measured; measured number inside the range.
By their numbers in this assay, from the lowest: compounds 3, 1 and 2 (each within the scatter of the next).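

In this assay, bromo on this aromatic carbon, para to a large group, gives a 1.2-fold lower number from compound 2 to compound 3 (0.08 log units; within the scatter) and a 1.1-fold lower number from compound 1 to compound 3 (0.05 log units; within the scatter). Hydrogen, chloro and bromo at this position therefore cannot be told apart in this read-out, and a second halogen adds nothing to what chloro alone showed. No evidence on a cause is available for these numbers. Still open, as far as these compounds go, is whether a group of another kind at this position, such as an amine or a carboxylic acid, would give a step beyond the scatter.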